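Cyclohexyl for Cyclopentyl on Compound 1

A few compounds are considered here, and "the series" means these few. Any claim that something is new, unique, unknown or untested is made for them only; others in the source may bear on it.

The starting point is compound 1 (`O=C(O)c1ccc(NC(=O)[C@H](CC2CCCC2)n2cnc(S(=O)(=O)C3CC3)c2)nc1`), a carboxylic acid carrying a cyclopropyl group on a sulfonyl sulfur. In a physicochemical assay for lipophilicity, at pH 7.4 (on this read-out lower numbers stand for lower lipophilicity and higher numbers for higher lipophilicity), compound 1 gives -0.2. Within the data shown here, its only measured neighbour is compound 2 (`O=C(O)c1ccc(NC(=O)[C@H](CC2CCCC2)n2cnc(S(=O)(=O)C3CCC3)c2)nc1`), which gives -0.1, so the two cannot be told apart on this read-out. The next compound to be measured is compound 3 (`O=C(O)c1ccc(NC(=O)[C@H](CC2CCCCC2)n2cnc(S(=O)(=O)C3CC3)c2)nc1`), and the change is cyclohexyl in place of cyclopentyl on a saturated chain carbon, two bonds along the chain from an aromatic nitrogen and a carbonyl carbon. Among the measured compounds shown here, no step has been measured at that carbon. The nearest guide is a number 0.10 log units higher from compound 1 to compound 2 (within the scatter), which also replaces one carbon ring by a larger one, though on a sulfonyl sulfur, so it bears on this change only loosely. On that basis a small rise is expected in this assay, of a size near the edge of the scatter. The expected step is a number 0.20 log units higher from compound 1 to compound 3 (within the scatter). For compound 3 the estimate is 0, with an expected range from -0.3 to 0.3.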

Compound 3, distribution coefficient: -0.25
The estimate for compound 3 lay 0.25 log units above the measured number; measured number inside the range.
By their numbers in this assay, from the lowest: compounds 3, 1 and 2 (each within the scatter of the next).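

In this assay the first step measured at this saturated chain carbon is a number 0.05 log units lower from compound 1 to compound 3 (within the scatter) and so cyclohexyl and cyclopentyl cannot be told apart at this position on this read-out. Read alongside a number 0.10 log units higher from compound 1 to compound 2 (within the scatter) this means that both changes of carbon ring size shown, one on a sulfonyl sulfur and the other on the saturated chain carbon, stay within the scatter, a pattern that rests on compound 1, compound 2 and compound 3 alone and that none of the three goes against. No measurement is available that could explain why the enlarged ring at this carbon leaves the read-out indistinguishable from that of compound 1.

The compounds shown leave open whether an open isobutyl chain, a smaller cyclobutyl ring or a tetrahydropyranyl ring at this carbon would also stay within the scatter of compound 1. They also leave open whether cyclohexyl at this carbon would give the same picture with cyclobutyl, rather than cyclopropyl, on the sulfonyl sulfur.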